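Carbonyl substituent variation in a positive allosteric modulator series

This account rests on a few compounds, and the source may have more. Where it says the series, first, only, none or still open, it means among the compounds named here.

Compound 1 `COC1CCN(C(=O)N2CC(c3nc(-c4cccc(Cl)c4)no3)C2)CC1`: in an assay on HEK293 cells for positive allosteric modulation of metabotropic glutamate receptor 5 (Homo sapiens), read by FLIPR (a higher number here means that more compound is needed for the effect, a lower number that less compound is needed), compound 1 reaches only the assay limit, > 10000 nM, a limit and not a number.
Compound 2 `CC1CCN(C(=O)N2CC(c3nc(-c4cccc(Cl)c4)no3)C2)CC1`: in this assay compound 2 gives 865 nM.
Compound 3 `O=C([C@H]1CC2CCC1C2)N1CC(c2nc(-c3cccc(Cl)c3)no2)C1`: in this assay compound 3 gives 74 nM.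

Compound 3 holds the lowest of the two numbers; its nearest neighbour is compound 2, with a 12-fold lower number from compound 2 to compound 3 (1.07 log units; beyond the scatter). Compound 1 sits at the limit, (the limit of > 10000 nM in this assay, at which 1 of the 3 values shown sits). Both changes at the carbonyl carbon seen so far are large, an at least 130-fold lower number from compound 1 to compound 3 (2.13 log units; beyond the scatter) among them, and even the small change within that group, an at least 11-fold lower number from compound 1 to compound 2 (1.06 log units; beyond the scatter), moves the number well beyond the scatter.

Compound 4 `O=C(c1ccc(F)cc1)N1CC(c2nc(-c3cccc(Cl)c3)no2)C1`: a group of 7 heavy atoms (6 carbon, 1 fluorine; one six-membered aromatic ring of carbon only) in place of a group of 7 heavy atoms (7 carbon; 2 five-membered non-aromatic rings of carbon only), on a carbonyl carbon. Among the measured compounds shown here, no measured step exchanges a saturated carbon group on the carbonyl carbon for an aromatic one, so the direction is not fixed by the measured steps; they show only that this position governs the number strongly. A modest rise from compound 3 is expected, a 3.4-fold higher number from compound 3 to compound 4 (0.53 log units; beyond the scatter). For compound 4 the estimate is 250 nM, with a range from 50 nM to 1500 nM.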

Compound 4, half-maximal effective concentration: > 10000 nM
Compound 4: a limit, no number; the forecaster's own chance of this, stated with the estimate: 10%; middle value at least 40-fold (1.60 log units) from the limit.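

In this assay, the 4-fluorophenyl group on the carbonyl carbon gives an at least 130-fold higher number from compound 3 to compound 4 (2.13 log units; beyond the scatter) and an at least 11-fold higher number from compound 2 to compound 4 (1.06 log units; beyond the scatter), so an aromatic ring of carbon only fares worse here than both the saturated carbon group of compound 3 and the 4-methylpiperidin-1-yl group of compound 2. Across the four compounds, a measurable number at this position is therefore confined to those two groups, with the 4-methoxypiperidin-1-yl group of compound 1 and the 4-fluorophenyl group of compound 4 both failing to give one. Compound 1 and compound 4 each give a limit and not a number, so the step between them cannot be read: the limit of > 10000 nM in this assay, at which 2 of the 4 values shown sit.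

The compounds shown leave open whether the loss belongs to the aromatic ring itself or to its fluorine, which an unsubstituted phenyl or a pyridine ring on the carbonyl carbon would separate. Also open, from the compounds shown here alone, are how a simple cyclohexyl group compares with compound 3 and whether the number for compound 3 depends on its defined stereocentre.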